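Replacing the (morpholin-4-yl)carbonyl group of compound 3

The source may hold more compounds than are shown below. What is called first, only, known or untested is meant among the compounds shown, and "the series" means these compounds.

Values in a functional assay on A549 cells (Homo sapiens) for cytotoxicity, read by MTT assay, with a stated time of 72 h; a higher number here means a weaker inhibitor, a lower number a stronger inhibitor:
compound 1 `COc1ncc(-c2ccc3nc(NC(=O)NCC(=O)N4CCCC4)nn3c2)cc1NS(=O)(=O)c1ccc(F)cc1`: 2190 nM
compound 2 `CCCNC(=O)Nc1nc2ccc(-c3cnc(OC)c(NS(=O)(=O)c4ccc(F)cc4)c3)cn2n1`: 220 nM
compound 3 `COc1ncc(-c2ccc3nc(NC(=O)NCC(=O)N4CCOCC4)nn3c2)cc1NS(=O)(=O)c1ccc(F)cc1`: 2570 nM

Compound 3 stands level with compound 1, the measured step being a 1.2-fold higher number from compound 1 to compound 3 (0.07 log units; within the scatter). It stands clearly apart from compound 2, with a 12-fold higher number from compound 2 to compound 3 (1.07 log units; beyond the scatter).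

Compound 4 `COc1ncc(-c2ccc3nc(NC(=O)NCCN4CCN(C)CC4)nn3c2)cc1NS(=O)(=O)c1ccc(F)cc1` carries (4-methylpiperazin-1-yl)methyl in place of (morpholin-4-yl)carbonyl on a saturated chain carbon bound to an amide-type nitrogen.

The closest evidence at this place is a 10-fold lower number from compound 1 to compound 2 (1.00 log units; beyond the scatter), alongside the step to compound 3 above. Going by the values given here, no measured compound carries the entering group, so a moderate move to a lower number in this assay is expected, smaller than those steps. The estimated step is a 3.7-fold lower number from compound 3 to compound 4 (0.56 log units; beyond the scatter). For compound 4 the expected value is 700 nM, with an estimated range of 150 nM to 3000 nM.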

Compound 4, half-maximal inhibitory concentration: 1050 nM
Compound 4: middle estimate off by 1.5-fold (0.18 log units), on the low side, and the stated range covers the measured number.
By their numbers in this assay, from the lowest: compound 2; then compound 4; then compounds 1 and 3 (each within the scatter of the next).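

At this saturated chain carbon bound to an amide-type nitrogen, a ring-bearing group without the carbonyl fares better than either carbonyl-linked ring: in this assay the (4-methylpiperazin-1-yl)methyl group gives a 2.4-fold lower number from compound 3 to compound 4 (0.39 log units; beyond the scatter) and a 2.1-fold lower number from compound 1 to compound 4 (0.32 log units; beyond the scatter). That gain stays partial, since the plain chain still holds the lower number, with a 4.8-fold higher number from compound 2 to compound 4 (0.68 log units; beyond the scatter). Nothing measured here speaks to the cause of these steps. The compounds shown leave open whether the step follows the loss of the carbonyl or the 4-methylpiperazin-1-yl ring itself, and where an open-chain amine such as dimethylamino at the chain end would fall.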